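This account rests on a few compounds, and the source may have more. Where it says the series, first, only, none or still open, it means among the compounds named here.

Compound 1 `COc1cccc(C(=O)n2c(-c3cn(C)c4ccc(OC)cc34)nc3ccccc32)c1`: 4600 nM
Compound 2 `COc1ccc2c(c1)c(-c1nc3ccccc3n1C(=O)c1cccc(Br)c1)cn2C`: 24800 nM

Both compounds were tested in a functional assay on A549 cells (Homo sapiens) for inhibition, read by MTT assay, with a stated time of 24 h; a lower number here means a stronger inhibitor of growth, a higher number a weaker inhibitor of growth. Of the two numbers, compound 1 has the lower, so it is the stronger growth inhibitor of the pair, and the gap to compound 2 lies beyond the scatter.

The untested compound 3 `COc1cccc(C(=O)n2c(-c3cn(C)c4ccc(Br)cc34)nc3ccccc32)c1` differs from compound 1 in one place: bromo in place of methoxy on an aromatic carbon. This is a bromo in place of methoxy on an aromatic carbon, in a six-membered aromatic ring of carbon only that is part of a fused or bridged system of two rings.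

Within the data shown here, one measured step bears on this change: a 5.4-fold higher number from compound 1 to compound 2 (0.73 log units; beyond the scatter). It is the same swap of groups, but it replaces the other methoxy of compound 1, so it is a guide to direction more than to exact size. Among the measured compounds shown here, no measurement yet shows this swap at the new place. A weaker result in this assay is therefore expected, probably by a smaller step than that one, with wide uncertainty.

The estimated change is a 2.2-fold higher number from compound 1 to compound 3 (0.34 log units; beyond the scatter). For compound 3 the expected value is 10000 nM, with an estimated range from 3000 nM to 30000 nM.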

Compound 3, concentration for 50% growth inhibition: 10800 nM
Beside the measured number, compound 3's estimate is 1.1-fold (0.03 log units) below it; low and high end bracket the measured number.
By their numbers in this assay, from the lowest: compound 1; then compound 3; then compound 2.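

In this assay, replacing methoxy with bromo on the six-membered aromatic ring of carbon only, part of a fused or bridged system of two rings, gives a 2.3-fold higher number from compound 1 to compound 3 (0.37 log units; beyond the scatter) and so takes compound 3 beyond the scatter of compound 1. This shows that the methoxy at this place cannot be exchanged for bromo without a loss of growth inhibition, which the earlier pair could not show, as it changed only the other methoxy of compound 1. That earlier swap gave a 5.4-fold higher number from compound 1 to compound 2 (0.73 log units; beyond the scatter), so in these two cases the change goes in the same direction at both methoxy groups, although nothing measured here explains that direction.

The compounds shown leave open how other groups would behave at this place, such as a hydroxyl, a fluoro or an amine, since bromo alone cannot predict them. They also leave open whether the two swaps would add up in a single compound carrying bromo at both places.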